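Chloro in place of fluoro: what compound 3 may tolerate

The source may report more compounds than this note shows. Statements on the series, on what has been measured and on what is new or still open speak of the compounds shown alone.

Measured so far:
Compound 1, `CCO/N=C(/c1ccc(Br)cc1)C1CCN(C(C)CCNC(=O)c2c(Cl)cncc2Cl)CC1`: 33800 nM
Compound 2, `CC(CCNC(=O)c1c(Cl)cncc1Cl)N1CCC(C(Oc2cccc(F)c2)c2ccc(C(F)(F)F)cc2)CC1`: 5400 nM

Both compounds were tested in an ADME assay on PBMC cells (Homo sapiens) for cytotoxicity; a higher number here means that more compound is tolerated, a lower number that less compound is tolerated. Compound 2 gives 5400 nM, the lower of the two numbers, so less of it is tolerated than of compound 1, which in this assay gives 33800 nM. The gap between them is beyond the usual scatter, but the two structures differ in several places at once, so no single change can be tied to that gap.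

Compound 3, `CC(CCNC(=O)c1c(Cl)cncc1Cl)N1CCC(C(Oc2cccc(Cl)c2)c2ccc(C(F)(F)F)cc2)CC1`, has not been measured yet. It differs from compound 2 in one place only: chloro in place of fluoro on an aromatic carbon. The two compounds share everything else.

Within the data shown here, no measured pair here shows what chloro in place of fluoro on an aromatic carbon does in this assay, so the expectation can rest only on the small size of the change. The step of a 1.2-fold lower number from compound 2 to compound 3 (0.08 log units; within the scatter) is expected to be small, most likely within the scatter, with a slight lean toward a lower number. Compound 3 is therefore estimated at 4500 nM in this assay, with a likely range from 1800 nM to 11000 nM.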

Compound 3, half-maximal cytotoxic concentration: 8100 nM
Estimate against measurement, compound 3: 1.8-fold (0.26 log units) below; low and high end bracket the measured number.
By their numbers in this assay, from the lowest: compounds 2 and 3 (each within the scatter of the next); then compound 1.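

Compound 2 and compound 3 form the only pair shown that differs in a single place, so this is the one clean reading of a change on this series. Going from 3-fluorophenoxy to 3-chlorophenoxy gives a 1.5-fold higher number from compound 2 to compound 3 (0.18 log units; within the scatter) in this assay, which means that at this position, on this shared core, the two halogens cannot be told apart by this measurement: one heavy atom replaces another on the aromatic carbon, and the difference in the read-out is no larger than repeated tests of one compound would produce. No measurement at hand offers an explanation for this result.

Going by these compounds, what remains open is whether this position tolerates any group without a real shift in this assay, or only these two halogens, since a single swap between two similar atoms says little about a methoxy group, a nitrile, an amine or a carboxylic acid placed on the same carbon. On these data alone, it is also open whether chloro in place of fluoro would read the same way at another place in the molecule, or on a core such as that of compound 1.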